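The source may hold more compounds than are shown below. What is called first, only, known or untested is meant among the compounds shown, and "the series" means these compounds.

Values in a functional assay on HeLa cells (Homo sapiens) for antiproliferative activity, read by cell counting, with a stated time of 3 days; on this read-out lower numbers stand for stronger inhibition and higher numbers for weaker inhibition:
- compound 1 `COc1ccc(Oc2ccccc2NC(C)=C2C(=O)CC(c3ccccc3)CC2=O)cc1OC` gives 54 nM
- compound 2 `COc1cc(Oc2ccccc2NC(C)=C2C(=O)CC(c3ccccc3)CC2=O)ccc1N` gives 33 nM
- compound 3 `CC(Nc1ccccc1Oc1ccc(N)cc1)=C1C(=O)CC(c2ccccc2)CC1=O` gives 39 nM

Compound 3 cannot be separated from the other two compounds, as shown by (a 1.4-fold lower number from compound 1 to compound 3 (0.14 log units; within the scatter)) and (a 1.2-fold higher number from compound 2 to compound 3 (0.07 log units; within the scatter)). Compound 4 `COc1cccc(Oc2ccccc2NC(C)=C2C(=O)CC(c3ccccc3)CC2=O)c1` carries 3-methoxyphenyl in place of 4-aminophenyl on an oxygen on an aromatic ring. The closest evidence is the change at this same place (a 1.4-fold lower number from compound 1 to compound 3 (0.14 log units; within the scatter)). The exchange of amino for methoxy on that ring (a 1.6-fold lower number from compound 1 to compound 2 (0.21 log units; within the scatter)) and the removal of methoxy from it (a 1.2-fold higher number from compound 2 to compound 3 (0.07 log units; within the scatter)) also bear on the change. Going by the values given here, all three steps are small, but no measured compound carries 3-methoxyphenyl alone, so the range is kept wide. In this assay the expected change stays within the scatter (a 1.5-fold higher number from compound 3 to compound 4 (0.19 log units; within the scatter)). The estimate for compound 4 is 60 nM, with an expected range from 25 nM to 150 nM.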

Compound 4, half-maximal inhibitory concentration: 93 nM
Compound 4: the middle estimate sits 1.6-fold (0.19 log units) below what was measured, and the stated range covers the measured number.
By their numbers in this assay, from the lowest: compounds 2, 3, 1 and 4 (each within the scatter of the next, the first and the last beyond it).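

The group on the oxygen now gives steps beyond the scatter in this assay, though modest ones: 3-methoxyphenyl in place of 4-aminophenyl gives a 2.4-fold higher number from compound 3 to compound 4 (0.38 log units; beyond the scatter), and hydrogen in place of amino on an aromatic carbon gives a 2.8-fold higher number from compound 2 to compound 4 (0.45 log units; beyond the scatter). Loss of a methoxy group stays within the scatter at a 1.7-fold higher number from compound 1 to compound 4 (0.24 log units; within the scatter), and that change reads alike in both of its pairs: the same change on two cores in this assay, a 1.2-fold higher number (0.07 log units; within the scatter) from compound 2 to compound 3 and a 1.7-fold higher number (0.24 log units; within the scatter) from compound 1 to compound 4, 1.5-fold (0.16 log units) apart, within the scatter of two such steps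

Of the compounds shown, only compound 2 and compound 3, which carry the amino group, are separated from compound 4, while compound 1, which lacks it, is not. Open, from the compounds shown here alone, is how a hydroxyl or a dimethylamino group in place of that amino group would read. Also open, going by these compounds, is how an unsubstituted phenyl on the oxygen would compare with 3-methoxyphenyl and 4-aminophenyl.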